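A trimethoxyphenyl group in place of dimethoxyphenyl

A few compounds are considered here, and "the series" means these few. Any claim that something is new, unique, unknown or untested is made for them only; others in the source may bear on it.

Measured in a functional assay on HeLa cells (Homo sapiens) for cytotoxicity, read by MTT assay, with a stated time of 72 h (a lower number here means a stronger inhibitor, a higher number a weaker inhibitor), so far:
Compound 1 `O=C(/C=C/c1cccc(Cl)c1Cl)Nc1cc2c(Nc3ccc(F)c(Cl)c3)ncnc2cc1O[C@H]1CCOC1` gives 30500 nM
Compound 2 `COc1ccc(/C=C/C(=O)Nc2cc3c(Nc4ccc(F)c(Cl)c4)ncnc3cc2O[C@H]2CCOC2)c(OC)c1` gives 26500 nM

Compound 2 stands at 26500 nM, within the scatter of compound 1. Compound 3 `COc1cc(/C=C/C(=O)Nc2cc3c(Nc4ccc(F)c(Cl)c4)ncnc3cc2O[C@H]2CCOC2)cc(OC)c1OC` differs from it in one group: 3,4,5-trimethoxyphenyl in place of 2,4-dimethoxyphenyl on a double-bonded chain carbon bound to a double-bonded chain carbon. Within the data shown here, the only measured step bearing on this change is a 1.2-fold lower number from compound 1 to compound 2 (0.06 log units; within the scatter), which also exchanged one substituted phenyl for another at this place. On that evidence, no step beyond the scatter is expected in this assay. The estimated step is a 1.1-fold lower number from compound 2 to compound 3 (0.04 log units; within the scatter). For compound 3 the expected value is 24000 nM, with an estimated range from 10000 nM to 50000 nM.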

Compound 3, half-maximal inhibitory concentration: 24500 nM
Compound 3: the middle estimate sits 1.0-fold (0.01 log units) below what was measured; low and high end bracket the measured number.
By their numbers in this assay, from the lowest: compounds 3, 2 and 1 (each within the scatter of the next).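

In this assay, adding a third methoxy group and moving to the 3,4,5-trimethoxyphenyl pattern gives a 1.1-fold lower number from compound 2 to compound 3 (0.03 log units; within the scatter), and replacing the chlorines outright gives a 1.2-fold lower number from compound 1 to compound 3 (0.10 log units; within the scatter). All three substituted phenyl groups at this place, on a double-bonded chain carbon bound to a double-bonded chain carbon, therefore sit within the scatter of one another, even with the added hydrogen-bond acceptor. No supporting data bear on why this result arises. As far as these compounds go, whether an amine or a carboxylic acid on this phenyl ring would give a step beyond the scatter remains open.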